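The source may hold more compounds than are shown below. What is called first, only, known or untested is meant among the compounds shown, and "the series" means these compounds.

Compound 2, with the structure `O=CCN1N=C(c2ccc3ccccc3c2)CC1c1ccccc1[N+](=O)[O-]`, gives 3630 nM in a functional assay on HEp-2 cells (Homo sapiens) for cytotoxicity, read by sulforhodamine B assay, with a stated time of 48 h; a higher number here means a weaker inhibitor, a lower number a stronger inhibitor. On the two numbers available it stands lowest, but its nearest neighbour, compound 1 with the structure `O=CCN1N=C(c2ccc3ccccc3c2)CC1c1cccc([N+](=O)[O-])c1`, gives 3870 nM, and the step of a 1.1-fold lower number from compound 1 to compound 2 (0.03 log units; within the scatter) stays within the scatter, so the two cannot be told apart. Compound 3, with the structure `O=CCN1N=C(c2ccc3ccccc3c2)CC1c1cccc(Cl)c1Cl`, has not yet been measured. It differs from compound 2 in one place: 2,3-dichlorophenyl in place of 2-nitrophenyl on a saturated ring carbon. Within the data shown here, the only measured step, a 1.1-fold lower number from compound 1 to compound 2 (0.03 log units; within the scatter), concerns a shift of the nitro group on the same saturated ring carbon and not an exchange of the whole ring substituent, so it bears on the change only loosely; it shows that this position tolerated a change without any step beyond the scatter. Compound 3 is therefore expected to give about 3500 nM in this assay, within a range from 1400 nM to 9000 nM, which means an expected step of a 1.0-fold lower number from compound 2 to compound 3 (0.02 log units; within the scatter).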

Compound 3, half-maximal inhibitory concentration: 12500 nM
Beside the measured number, compound 3's estimate is 3.6-fold (0.55 log units) below it, outside the stated range (above it).
By their numbers in this assay, from the lowest: compounds 2 and 1 (each within the scatter of the next); then compound 3.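

The exchange of the whole ring substituent moves the number in this assay where the shift of the nitro group did not, with a 3.4-fold higher number from compound 2 to compound 3 (0.54 log units; beyond the scatter) for 2,3-dichlorophenyl in place of 2-nitrophenyl and a 3.2-fold higher number from compound 1 to compound 3 (0.51 log units; beyond the scatter) for 2,3-dichlorophenyl in place of 3-nitrophenyl. The saturated ring carbon next to the ring nitrogen is therefore not indifferent to what it carries, although both steps are modest and compound 3 alone stands apart from the two nitrophenyl compounds. No measurement at hand accounts for this change.

The compounds shown leave open whether a single chlorine on the phenyl ring would give a similar step, and how a phenyl ring bearing an amine or a carboxylic acid would read at this carbon. They also leave open whether the step would persist with a longer chain in place of the formylmethyl group.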